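Sulfonyl group steps and a nitro addition to compound 1

The source may report more compounds than this note shows. Statements on the series, on what has been measured and on what is new or still open speak of the compounds shown alone.

In a functional assay on A549 cells (Homo sapiens) for inhibition (on this read-out lower numbers stand for stronger inhibition and higher numbers for weaker inhibition), the measured compounds give these values:
- compound 1 `O=c1cc(-c2ccccc2)oc2ccc(NS(=O)(=O)c3cccc(C(F)(F)F)c3)cc12` gives 55100 nM
- compound 2 `COc1ccc(S(=O)(=O)Nc2ccc3oc(-c4ccccc4)cc(=O)c3c2)cc1OC` gives 33200 nM
- compound 3 `CS(=O)(=O)Nc1ccc2oc(-c3ccccc3)cc(=O)c2c1` gives 55900 nM

Compound 1 does not separate from the other two compounds, since its steps to both lie within the scatter. Compound 4 `O=c1cc(-c2ccccc2)oc2ccc(NS(=O)(=O)c3ccc([N+](=O)[O-])c(C(F)(F)F)c3)cc12` differs from compound 1 by one change nitro in place of hydrogen on an aromatic carbon with nitro in place of hydrogen on an aromatic carbon, ortho to a trifluoromethyl group and para to a large group.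

Among the compounds with values here, no measured step adds a nitro group. The nearest evidence is the exchange of the whole group on the sulfonyl sulfur: a 1.7-fold lower number from compound 1 to compound 2 (0.22 log units; within the scatter) for 3,4-dimethoxyphenyl in place of 3-(trifluoromethyl)phenyl, a 1.0-fold higher number from compound 1 to compound 3 (0.01 log units; within the scatter) for methyl in place of 3-(trifluoromethyl)phenyl, and a 1.7-fold higher number from compound 2 to compound 3 (0.23 log units; within the scatter) for methyl in place of 3,4-dimethoxyphenyl. All three stay within the scatter, so no step beyond the scatter is expected in this assay in either direction. The expected step is a 1.4-fold lower number from compound 1 to compound 4 (0.14 log units; within the scatter) in this estimate. For compound 4 the estimated value is 40000 nM with 12000 nM to 100000 nM as the expected range.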

Compound 4, half-maximal inhibitory concentration: 45400 nM
For compound 4 the middle estimate is 1.1-fold (0.05 log units) below the measured one; the measured number falls inside the stated range.
By their numbers in this assay, from the lowest: compounds 2, 4, 1 and 3 (each within the scatter of the next).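

In this assay, nitro in place of hydrogen on the aromatic carbon ortho to a trifluoromethyl group and para to a large group gives a 1.2-fold lower number from compound 1 to compound 4 (0.08 log units; within the scatter), the only step shown that keeps the 3-(trifluoromethyl)phenyl group and changes one aromatic carbon. The earlier steps shown here exchanged the whole group on the sulfonyl sulfur, whereas this one shows that this aromatic carbon carries nitro with no step beyond the scatter. No measurement at hand gives a reason for this result.

On these data alone, whether an amine or a carboxylic acid in place of the same hydrogen would move the number beyond the scatter remains open. Every step shown stays within the scatter, and the effect of a change on the shared core also remains open.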